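Amide aryl variation in the flavonol series: compound 3

The compounds below may be only part of what the source reports. "The series", "measured", "known", "first", "only" and "open" are said of these compounds alone.

Of the compounds shown here, two carry numbers so far. Compound 1 `O=C(Nc1cccc(-c2oc3cc(-c4ccc(F)cc4)ccc3c(=O)c2O)c1)c1ccc(F)cc1` gives 14200 nM in a functional assay on HCC1937 cells (Homo sapiens) for antiproliferative activity, read by CCK-8 assay, with a stated time of 72 h; a higher number here means a weaker inhibitor, a lower number a stronger inhibitor. Compound 2 `COc1ccc(C(=O)Nc2cccc(-c3oc4cc(-c5ccc(F)cc5)ccc4c(=O)c3O)c2)c(F)c1` gives 24500 nM in the same assay, which is the higher of the two numbers recorded, though the step of a 1.7-fold higher number from compound 1 to compound 2 (0.24 log units; within the scatter) is within the scatter, so the two compounds cannot be ordered on these data.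

Compound 3 `O=C(Nc1cccc(-c2oc3cc(-c4ccc(F)cc4)ccc3c(=O)c2O)c1)c1ccc(Cl)nc1` has not yet been measured. It differs from compound 2 in the change (6-chloropyridin-3-yl in place of 2-fluoro-4-methoxyphenyl on a carbonyl carbon). Going by the values given here, the only measured step, from compound 1 to compound 2, also sits on this carbonyl carbon and exchanges one aromatic ring for another there; that step was within the scatter. On that basis the exchange leading to compound 3 is not expected to move the number beyond the scatter either, and no direction can be read from a single step that itself lies within the noise.

For compound 3 the estimated value in this assay is 18000 nM, with a range from 7000 nM to 45000 nM. The expected step is a 1.4-fold lower number from compound 2 to compound 3 (0.13 log units; within the scatter), which is a small change and carries no claimed direction.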

Compound 3, half-maximal inhibitory concentration: 7550 nM
For compound 3 the middle estimate is 2.4-fold (0.38 log units) above the measured one; the measured number falls inside the stated range.
By their numbers in this assay, from the lowest: compounds 3, 1 and 2 (each within the scatter of the next, the first and the last beyond it).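

In this assay, 6-chloropyridin-3-yl in place of 2-fluoro-4-methoxyphenyl on the carbonyl carbon gives a 3.2-fold lower number from compound 2 to compound 3 (0.51 log units; beyond the scatter). Going by these compounds alone, this is the only step so far that lies beyond the scatter, and it shows that the number can respond to the aryl group at this position, though modestly. The same ring in place of 4-fluorophenyl gives a 1.9-fold lower number from compound 1 to compound 3 (0.27 log units; within the scatter), so the difference holds only against compound 2, compound 3 cannot be called the strongest of the three, and no data here explain the step.

The exchange alters the ring atoms and all the ring substituents at once, so the compounds shown do not separate the contribution of the ring nitrogen, the chlorine, or the loss of the methoxy and fluoro groups. Also open, from the compounds shown here alone, is how the number would respond to a plain pyridin-3-yl ring, to an amine or a carboxylic acid on the ring, or to a saturated ring in place of the aryl group on this carbonyl carbon.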